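Swapping the Benzyl Ether on an Inactive Cinnamate Ester

This account rests on a few compounds, and the source may have more. Where it says the series, first, only, none or still open, it means among the compounds named here.

Compound 2, `COc1cc(/C=C/C(=O)OCC(=O)Nc2ccc(Cl)cc2)cc(OC)c1OCc1ccc(Cl)c(Cl)c1`, was tested in a functional assay on HeLa cells (Homo sapiens) for cytotoxicity, read by MTT assay, with a stated time of 72 h; a higher number here means a weaker inhibitor, a lower number a stronger inhibitor. Here compound 2 reaches only the limit of the assay, > 200000 nM, so no true number is known for it. Compound 1, `CCOc1ccc(COc2c(OC)cc(/C=C/C(=O)OCC(=O)Nc3ccccc3)cc2OC)cc1`, is the other compound with a result in this assay, and for compound 1 the outcome is likewise a limit, > 200000 nM. Both measured values therefore sit at the same boundary, (the limit of > 200000 nM in this assay, at which 2 of the 2 values shown sit).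

Compound 3, `CCOc1ccc(COc2c(OC)cc(/C=C/C(=O)OCC(=O)Nc3ccc(Cl)cc3)cc2OC)cc1`, is not yet measured. It differs from compound 2 in one place: 4-ethoxyphenyl in place of 3,4-dichlorophenyl on a saturated chain carbon bound to an oxygen on an aromatic ring. The rest of the shared core is kept from compound 2, while the benzyl ether now matches that of compound 1.

For the measured compounds named here, no measured step between two compounds is available, so the size of this change cannot be read from data. Since compound 1 carries the same 4-ethoxybenzyl group and sits at the same boundary (the limit of > 200000 nM in this assay, at which 2 of the 2 values shown sit), the expected step from compound 2 to compound 3 is a number no higher from compound 2 to compound 3 (the limit leaves the size open), none beyond the scatter. Compound 3 is therefore expected to give 200000 nM, within 50000 nM to 1000000 nM, most likely again as a limit.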

Compound 3, half-maximal inhibitory concentration: > 200000 nM
Compound 3 was reported as a limit; the forecaster's own chance of this, stated with the estimate: 80%; the middle value lies on the limit itself.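

Compound 3 also stops at a limit in this assay, so no size can be read for its steps from compound 1 or compound 2, because all three compounds sit at the same boundary: the limit of > 200000 nM in this assay, at which 3 of the 3 values shown sit.

On these data alone, what stays open is the true strength of each compound, and whether exchanging 3,4-dichlorophenyl for 4-ethoxyphenyl, or hydrogen for chloro, changes it at all.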